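The source may hold more compounds than are shown below. What is called first, only, known or untested is meant among the compounds shown, and "the series" means these compounds.

Measured so far, in a functional assay on MDA-MB-231 cells (Homo sapiens) for antiproliferative activity, with a stated time of 72 h; a higher number here means that more compound is needed for the effect, a lower number that less compound is needed:
Compound 1 `COC(=O)c1ccc(N(Cc2ccc(C3CCCCC3)cc2)C(=O)[C@H]2CCN2S(=O)(=O)c2c(F)c(F)c(F)c(F)c2F)cc1O` gives 2700 nM.
Compound 2 `COC(=O)c1ccc(N(Cc2ccc(C3CCCCC3)cn2)C(=O)[C@H]2CCN2S(=O)(=O)c2c(F)c(F)c(F)c(F)c2F)cc1O` gives 1800 nM.
Compound 3 `CC(C)(C)c1ccc(CN(C(=O)[C@H]2CCN2S(=O)(=O)c2c(F)c(F)c(F)c(F)c2F)c2ccc(C(=O)NO)cc2F)cc1` has no reported result: "not determined" (no result reported).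

Among the measured compounds shown here, compound 2 holds the lowest of the two numbers available, but its nearest neighbour is compound 1, and the one measured step, a 1.5-fold lower number from compound 1 to compound 2 (0.18 log units; within the scatter), lies within the scatter, so the two cannot be ranked against each other. Compound 4 `O=C([C@H]1CCN1S(=O)(=O)c1c(F)c(F)c(F)c(F)c1F)N(Cc1ccc(C2CCCCC2)cn1)c1ccc2c(=O)[nH]ccc2c1` keeps the shared core of compound 2 and alters only one part: a group of 11 heavy atoms (9 carbon, 1 nitrogen, 1 oxygen; one six-membered aromatic ring of carbon only, one six-membered aromatic ring with 1 hetero atom) in place of a group of 11 heavy atoms (8 carbon, 3 oxygen; one six-membered aromatic ring of carbon only), on an amide-type nitrogen.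

For the measured compounds named here, no measured step touches this part of the molecule. Going by the values given here, the only step in hand, from compound 1 to compound 2, concerns the group on the saturated chain carbon and so gives no guide for what happens on the amide-type nitrogen. With nothing to anchor a direction, the expectation for compound 4 is a number near that of compound 2, with a wide spread to cover the unknown effect of the new group; the step of a 1.2-fold lower number from compound 2 to compound 4 (0.08 log units; within the scatter) is therefore expected to be small. The estimate for compound 4 is 1500 nM, with a range from 400 nM to 6000 nM.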

Compound 4, half-maximal effective concentration: 1200 nM
Estimate against measurement, compound 4: 1.3-fold (0.10 log units) above; measured number inside the range.
By their numbers in this assay, from the lowest: compounds 4, 2 and 1 (each within the scatter of the next, the first and the last beyond it).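

In this assay, among the compounds shown here, the step of a 1.5-fold lower number from compound 2 to compound 4 (0.18 log units; within the scatter) is the first measured change on the amide-type nitrogen, and it lies within the scatter. The 3-hydroxy-4-(methoxycarbonyl)phenyl group can therefore give way, in this pair, to a group with a second aromatic ring and a ring nitrogen, with 1 hydrogen-bond donor on each side and hydrogen-bond acceptors going from 3 to 1, and the number stays within the scatter. No available evidence says why these two different groups read alike.

As far as these compounds go, the whole group changes in this single step, so the separate roles of the hydroxy and the methoxycarbonyl parts remain open. Also open, from the compounds shown here alone, is how this nitrogen position would respond to a group carrying a carboxylic acid or an amine.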